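The compounds below may be only part of what the source reports. "The series", "measured", "known", "first", "only" and "open" are said of these compounds alone.

Measured in an ADME assay on HEK293 cells (Homo sapiens) for cytotoxicity, read by reporter gene assay and resazurin assay, with a stated time of 48 h; on this read-out lower numbers stand for higher toxicity in this test and higher numbers for lower toxicity in this test:
- compound 1 `O=C(Nc1cccc(Cl)c1)c1cc(Br)cc(Br)c1O`: 18000 nM
- compound 2 `COc1c(Br)cc(Br)cc1C(=O)Nc1ccccc1`: > 100000 nM (a limit)
- compound 3 `COc1c(Br)cccc1C(=O)Nc1ccccc1`: > 100000 nM (a limit)

Compound 2 has no readable number: it gives > 100000 nM, which is a limit of the assay. The series stands mostly at the limit of > 100000 nM in this assay, at which 2 of the 3 values shown sit. Compound 1 alone gives a number, but it differs from compound 2 in more than one place, so it offers no direct guide.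

Compound 4 `O=C(Nc1ccccc1)c1cc(Br)cc(Br)c1` is compound 2 with one change: hydrogen in place of methoxy on an aromatic carbon. Within the data shown here, no measured step covers this exchange. The closest is a step that the two limits leave unreadable from compound 2 to compound 3, a different exchange on the same ring, and it has no readable size. Compound 3 gives > 100000 nM, which is again a limit.

With nothing pointing to a shift in this assay, no change beyond the scatter is expected, and a further limit reading is the likeliest outcome. The expected step is an at least 1.1-fold lower number from compound 2 to compound 4 (0.04 log units; that floor lies within the scatter). For compound 4 the estimated value is 90000 nM, with an expected range from 30000 nM to 150000 nM.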

Compound 4, half-maximal cytotoxic concentration: > 100000 nM
Compound 4: only a limit was reported; the forecaster's own chance of this, stated with the estimate: 70%; middle value at least 1.1-fold (0.04 log units) away from the limit.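

Compound 4 gives > 100000 nM in this assay, a limit. Among these compounds, compound 2 gives > 100000 nM, also a limit, so no step between compound 2 and compound 4 can be read. The compounds shown leave open whether hydrogen in place of methoxy shifts this read-out at all.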